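The compounds below may be only part of what the source reports. "The series", "measured", "known", "first", "only" and "open" are said of these compounds alone.

In an assay on HEK293 cells with Neuronal acetylcholine receptor; alpha4/beta2 (Homo sapiens) as the target, read by FLIPR and calcium flux (a lower number here means a smaller maximal response, a higher number a larger maximal response), compound 1 `COc1cc(N2CCCNCC2)cnc1Cl` gives 116%, compound 2 `Clc1ncc(N2CCCNCC2)cc1Br` gives 85%, and compound 3 `Brc1cncc(N2CCCNCCC2)c1` gives 73%, the lowest of the three. Compounds 2 and 1 differ in one place, (methoxy in place of bromo on an aromatic carbon), and that change brought a number 31 percentage points higher from compound 2 to compound 1 (beyond the scatter). How the core of compound 3 differs from that of compound 2 is not broken down here. Compound 4 `COc1cncc(N2CCCNCCC2)c1` is the unmeasured partner of compound 3: methoxy in place of bromo on an aromatic carbon. This is the same kind of change as before, though the place is not identical: in compound 2 it is ortho to a chloro group and meta to a group of 7 heavy atoms, in compound 3 meta to a group of 8 heavy atoms. Because the earlier change gave a number 31 percentage points higher from compound 2 to compound 1 (beyond the scatter), compound 4 is expected to show a number 23 percentage points higher from compound 3 to compound 4 (beyond the scatter) in this assay, somewhat smaller, as a single example supports it. The estimate for compound 4 is 96%, between 76% and 116%.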

Compound 4, largest response reached (reported as efficacy), in percent of the reference or control that the assay uses: 89%
For compound 4 the middle estimate is 7 percentage points above the measured one; the range from low to high includes it.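

In this assay, methoxy in place of bromo again gave a number 16 percentage points higher from compound 3 to compound 4 (beyond the scatter), so the direction of the change carried over to the second core. Its size did not carry over: the same change on two cores in this assay, a number 31 percentage points higher (beyond the scatter) from compound 2 to compound 1 and a number 16 percentage points higher (beyond the scatter) from compound 3 to compound 4, 15 percentage points apart, beyond the scatter of two such steps

Two pairs cannot show whether this gap in size goes with the chloro group carried by compound 1 and compound 2 or with another difference between the cores. The compounds shown leave open how an ethoxy group, a nitrile or an amine would behave at this place, and whether methoxy in place of bromo would move the number the same way on further cores. They also leave potency open, as only the largest response is given.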